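From Hydroxy to Cyano on a Shared Core

The source may hold more compounds than are shown below. What is called first, only, known or untested is meant among the compounds shown, and "the series" means these compounds.

Measured so far in a functional assay (aorta) with Rattus norvegicus as the target; on this read-out higher numbers stand for higher potency (the scale is a negative logarithm) and lower numbers for lower potency:
compound 1 `CC1(C)C=C(n2ccccc2=O)c2cc(C(=O)c3cccs3)ccc2O1` gives 6.4
compound 2 `CC1(C)C=C(n2ccccc2=O)c2cc(O)ccc2O1` gives 5.44

Compound 2 stands lowest of these two numbers; its nearest neighbour is compound 1, which lies higher by a step beyond the scatter. Compound 3 `CC1(C)C=C(n2ccccc2=O)c2cc(C#N)ccc2O1` differs from compound 2 in one place: cyano in place of hydroxy on an aromatic carbon. Among the compounds with values here, only one measured step bears on this: a number 0.96 log units lower from compound 1 to compound 2 (beyond the scatter), a change of hydroxy in place of (thiophen-2-yl)carbonyl on an aromatic carbon. That step shows that the hydroxy at this position goes with the lower number, and that another group at the same aromatic carbon can give a clearly higher one. Cyano is a different group from (thiophen-2-yl)carbonyl, so the size of the gain is uncertain, but a rise beyond the scatter is expected, giving a number 0.56 log units higher from compound 2 to compound 3 (beyond the scatter). Compound 3 is therefore estimated at 6 in this assay, within a range from 5.3 to 6.7.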

Compound 3, logarithm of the reciprocal of the active concentration, log(1/C): 7.67
Beside the measured number, compound 3's estimate is 1.67 log units below it, and the stated range ends below it.
By their numbers in this assay, from the lowest: compound 2; then compound 1; then compound 3.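

In this assay, the group on this aromatic carbon matters more than the earlier pair could reveal: cyano in place of hydroxy gives a number 2.23 log units higher from compound 2 to compound 3 (beyond the scatter). Cyano also outperforms the larger (thiophen-2-yl)carbonyl, with a number 1.27 log units higher from compound 1 to compound 3 (beyond the scatter), so a high number at this position does not require a group of that size. The data shown offer no measurement that explains why cyano stands so far above the other two groups.

The compounds shown leave open where other groups on this carbon, such as an amine, a carboxylic acid or a methyl ester, would fall relative to these three. They also leave open whether a longer chain ending in a nitrile would keep the high number seen with cyano.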